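From Carboxylic Acid to Aldehyde on the Side Chain

A few compounds are considered here, and "the series" means these few. Any claim that something is new, unique, unknown or untested is made for them only; others in the source may bear on it.

In a functional assay on RAW264.7 cells (Mus musculus) for inhibition, read by Griess assay, with stated times of 30 min and 24 h (a higher number here means a weaker inhibitor, a lower number a stronger inhibitor), compound 1 `CC(=O)OCC[C@@H](C)CC[C@@H]1[C@@]2(C)CCCC(C)(C)[C@@H]2CC[C@@]1(C)O` gives 15000 nM. Compound 2 `C[C@@H](CC[C@@H]1[C@@]2(C)CCCC(C)(C)[C@@H]2CC[C@@]1(C)O)CC(=O)O` reaches only a limit of the assay, giving > 50000 nM. Going by the values given here, the single measured step, an at least 3.3-fold higher number from compound 1 to compound 2 (0.52 log units; beyond the scatter), ends at the limit of > 50000 nM in this assay, at which 1 of the 2 values shown sits. Compound 3 `C[C@H](CC=O)CC[C@@H]1[C@@]2(C)CCCC(C)(C)[C@@H]2CC[C@@]1(C)O` differs from compound 2 by hydrogen in place of hydroxy on a carbonyl carbon. Among the compounds with values here, no measured step covers this exact change, and the limit leaves open how far compound 2 lies beyond it. The step from the acid to the aldehyde is expected to run towards a stronger inhibitor, estimated as an at least 2.0-fold lower number from compound 2 to compound 3 (0.30 log units; that floor lies within the scatter). Compound 3 is therefore expected to give about 25000 nM, within 8000 nM to 80000 nM.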

Compound 3, half-maximal inhibitory concentration: > 50000 nM
Compound 3: a limit, no number; the forecaster's own chance of this, stated with the estimate: 35%; middle value at least 2.0-fold (0.30 log units) from the limit.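

The aldehyde does not bring the side chain back into the measurable range: compound 3 stands at a limit of the assay, as compound 2 does, so the step between them cannot be read. Replacing acetoxymethyl with formyl at this chain end gives a weaker result, with an at least 3.3-fold higher number from compound 1 to compound 3 (0.52 log units; beyond the scatter). Readable comparisons at this position therefore remain scarce: the limit of > 50000 nM in this assay, at which 2 of the 3 values shown sit.

From the compounds shown here alone, how far compound 2 and compound 3 lie beyond that limit remains open. So does whether a primary alcohol, an amine or an amide at this chain end would match compound 1.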